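Moving the trifluoromethyl group on the phenyl ring

A few compounds are considered here, and "the series" means these few. Any claim that something is new, unique, unknown or untested is made for them only; others in the source may bear on it.

Compounds measured so far in a functional assay on HL-60 cells (Homo sapiens) for inhibition, read by MTT assay, with a stated time of 72 h; a lower number here means a stronger inhibitor, a higher number a weaker inhibitor:
compound 1 (`Cc1nc(-c2ccccc2)c(C(=O)N2CCN(c3cccc(Cl)c3Cl)CC2)o1`) gives (133 nM)
compound 2 (`Cc1nc(-c2ccccc2)c(C(=O)N2CCN(c3cccc(C)c3C)CC2)o1`) gives (35 nM)
compound 3 (`Cc1nc(-c2ccccc2)c(C(=O)N2CCN(c3ccc(C(F)(F)F)cc3)CC2)o1`) gives (> 1000 nM), a limit of the assay and not a number

Compound 3 has no exact value, and it stands at the weak end of this small set (the limit of > 1000 nM in this assay, at which 1 of the 3 values shown sits). Compound 4 (`Cc1nc(-c2ccccc2)c(C(=O)N2CCN(c3cccc(C(F)(F)F)c3)CC2)o1`) differs from it only in where one group sits (3-(trifluoromethyl)phenyl in place of 4-(trifluoromethyl)phenyl on an amine nitrogen in a ring): 3-(trifluoromethyl)phenyl in place of 4-(trifluoromethyl)phenyl on an amine nitrogen in a ring. The two have the same atoms, joined differently.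

Among the measured compounds shown here, two measured steps bear on this change. Replacing 2,3-dichlorophenyl gave (an at least 7.5-fold higher number from compound 1 to compound 3 (0.87 log units; beyond the scatter)), an at least modest loss, and replacing 2,3-dimethylphenyl gave (an at least 28-fold higher number from compound 2 to compound 3 (1.45 log units; beyond the scatter)), a large one. Swapping between those two groups gave a smaller, modest step (a 3.8-fold lower number from compound 1 to compound 2 (0.58 log units; beyond the scatter)). The names show that compound 4 carries a group numbered 3, as do compound 1 (133 nM) and compound 2 (35 nM), while compound 3 does not. For the measured compounds named here, this rests on only two compounds, and neither carries trifluoromethyl, so only a partial recovery is expected. In this assay the expected step is toward a lower number (an at least 2.5-fold lower number from compound 3 to compound 4 (0.39 log units; beyond the scatter)), and its size is uncertain. For compound 4 the estimated value is (400 nM), within an expected range from (100 nM) to (1500 nM).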

Compound 4, half-maximal inhibitory concentration: 153 nM
Beside the measured number, compound 4's estimate is 2.6-fold (0.42 log units) above it, and the stated range covers the measured number.
By their numbers in this assay, from the lowest: compound 2; then compounds 1 and 4 (each within the scatter of the next). At a limit, above all of these: compound 3.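

Moving the trifluoromethyl group, with no atom added or lost, gives an at least 6.5-fold lower number from compound 3 to compound 4 (0.81 log units; beyond the scatter) in this assay, so where this one group sits on the phenyl ring matters in this series. Among the compounds shown here, compound 3 has only a limit of the assay and not a number, so that step gives a minimum size: the limit of > 1000 nM in this assay, at which 1 of the 4 values shown sits. The earlier compounds also could not show how 3-(trifluoromethyl)phenyl compares with the two groups that carry a pair of substituents: against 2,3-dichlorophenyl the change is a 1.2-fold higher number from compound 1 to compound 4 (0.06 log units; within the scatter), so the single group matches that pair within the scatter, while against 2,3-dimethylphenyl it is a 4.4-fold higher number from compound 2 to compound 4 (0.64 log units; beyond the scatter), so compound 2 keeps a real edge.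

The compounds shown do not tell whether a group numbered 3 helps in general or only for these substituents, since a phenyl carrying a methoxy group or a nitrile at that place does not appear among them. As far as these compounds go, an unsubstituted phenyl is also missing, so it stays open whether the 3-(trifluoromethyl)phenyl group adds anything over the bare ring or whether the 4-(trifluoromethyl)phenyl group simply takes something away.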